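Nitro in place of amino on compound 1

The source may hold more compounds than are shown below. What is called first, only, known or untested is meant among the compounds shown, and "the series" means these compounds.

In a functional assay on SK-BR-3 cells (Homo sapiens) for antiproliferative activity, with a stated time of 48 h (a lower number here means that less compound is needed, a higher number that more compound is needed for the effect), compound 1 (`Nc1ccc(NC(=O)CCCCCCC(=O)NO)cc1`) gives 8500 nM, the second highest of three numbers. Compound 2 (`O=C(CCCCCCC(=O)Nc1cccc(F)c1)NO`) gives a lower number, 1900 nM, and compound 3 (`O=C(CCCCCCC(=O)Nc1ccccc1Br)NO`) a higher one, 17500 nM, both beyond the scatter from compound 1. Compound 4 (`O=C(CCCCCCC(=O)Nc1ccc([N+](=O)[O-])cc1)NO`) is still unmeasured and carries nitro in place of amino on an aromatic carbon, para to a large group: nitro in place of amino on an aromatic carbon. Going by the values given here, no measured pair differs in one place, so support is thin. A small step towards a lower number is expected in this assay, perhaps not beyond the scatter. The estimated change is a 1.7-fold lower number from compound 1 to compound 4 (0.23 log units; within the scatter). Compound 4 is expected at 5000 nM, with an estimated range of 1500 nM to 15000 nM.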

Compound 4, half-maximal effective concentration: 58000 nM
Compound 4: middle estimate off by 12-fold (1.06 log units), on the low side, outside the stated range (above it).
By their numbers in this assay, from the lowest: compound 2; then compound 1; then compound 3; then compound 4.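

In this assay, going by these compounds alone, nitro in place of amino on an aromatic carbon, para to a large group, gives a 6.8-fold higher number from compound 1 to compound 4 (0.83 log units; beyond the scatter), the first one-place step. This position is therefore sensitive to the exchange, and the amino group of compound 1 is the better of the two groups here. No measurement on these compounds accounts for the size of the step.

From the compounds shown here alone, how a nitrile, a methoxy group or a plain hydrogen would read at this place remains open. So does whether the same exchange elsewhere on the ring gives a similar step.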